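Swapping a Hydroxyphenyl Ketone for a Fluorophenyl Ketone

This account rests on a few compounds, and the source may have more. Where it says the series, first, only, none or still open, it means among the compounds named here.

Compound 1, `CC1(C)C=C(n2ccccc2=O)c2ccccc2O1`, gives 5.05 in a functional assay (trachea) with Rattus norvegicus as the target; on this read-out lower numbers stand for lower potency and higher numbers for higher potency (the scale is a negative logarithm).
Compound 2, `CC1(C)C=C(n2ccccc2=O)c2cc(C(=O)c3ccccc3)ccc2O1`, gives 6.21 in this assay.
Compound 3, `CC1(C)C=C(n2ccccc2=O)c2cc(C(=O)c3ccc(O)cc3)ccc2O1`, gives 5.87 in this assay.

Compound 3 stands second highest of the three numbers: the step of a number 0.34 log units lower from compound 2 to compound 3 (beyond the scatter) separates it from the top, and the step of a number 0.82 log units higher from compound 1 to compound 3 (beyond the scatter) separates it from the bottom. Compound 4, `CC1(C)C=C(n2ccccc2=O)c2cc(C(=O)c3ccccc3F)ccc2O1`, differs from compound 3 by 2-fluorophenyl in place of 4-hydroxyphenyl on a carbonyl carbon. Going by the values given here, two measured steps bear on this change. The step of a number 1.16 log units higher from compound 1 to compound 2 (beyond the scatter) shows that a benzoyl group with no further substituent brings a large gain over the unsubstituted core, and the step of a number 0.34 log units lower from compound 2 to compound 3 (beyond the scatter) shows that adding a hydroxy to that benzoyl costs a modest amount. Among the compounds with values here, compound 4 removes the hydroxy again and carries a fluorine instead, for which no measured step exists, so it is expected to land close to compound 2, a modest rise of a number 0.23 log units higher from compound 3 to compound 4 (within the scatter). Compound 4 is therefore estimated at 6.1, within the range 5.6 to 6.6.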

Compound 4, logarithm of the reciprocal of the active concentration, log(1/C): 6.34
Compound 4: middle estimate off by 0.24 log units, on the low side; measured number inside the range.
By their numbers in this assay, from the lowest: compound 1; then compound 3; then compounds 2 and 4 (each within the scatter of the next).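

In this assay the change to 2-fluorophenyl on a carbonyl carbon brings a number 0.47 log units higher from compound 3 to compound 4 (beyond the scatter) and so shows that this ring can do without the hydrogen-bond donor of compound 3. Fluoro in place of hydrogen on the plain benzoyl group gives a number 0.13 log units higher from compound 2 to compound 4 (within the scatter) and so leaves the number indistinguishable from that of compound 2, while the whole (2-fluorophenyl)carbonyl group still gives a number 1.29 log units higher from compound 1 to compound 4 (beyond the scatter) and keeps the large gain over the bare core. Nothing measured here explains why the fluoro and hydroxy versions differ.

Still open, as far as these compounds go, is how an amine, a carboxylic acid or a methoxy group on this phenyl ring would read. From the compounds shown here alone, it is also open whether a fluoro elsewhere on the ring would give the same number.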